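Hydroxy to methylsulfonyl: what to expect of compound 4

The source may report more compounds than this note shows. Statements on the series, on what has been measured and on what is new or still open speak of the compounds shown alone.

In a functional assay on Caco-2 cells (Homo sapiens) for cytotoxicity, with a stated time of 48 h (on this read-out higher numbers stand for weaker inhibition and lower numbers for stronger inhibition), compound 1 `N#Cc1ccc(-c2cncc(-c3cc4ccc(O)cc4[nH]3)c2)cc1` gives 10000 nM and compound 2 `CS(=O)(=O)c1ccc(-c2cncc(-c3cc4ccc(O)cc4[nH]3)c2)cc1`, which shares its core, gives 3000 nM on the same read-out. Compound 3 `Oc1ccc(-c2cncc(-c3cc4ccc(O)cc4[nH]3)n2)cc1` has a different core and reads 7000 nM in this assay, a number within the scatter of compound 1. Its number is higher than that of compound 2, by a gap beyond the scatter.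

Compound 4 `CS(=O)(=O)c1ccc(-c2cncc(-c3cc4ccc(O)cc4[nH]3)n2)cc1` keeps the core of compound 3 and carries methylsulfonyl in place of hydroxy on an aromatic carbon, para to a large group (methylsulfonyl in place of hydroxy on an aromatic carbon).

For the measured compounds named here, no measured pair shows this exact exchange. Going by the values given here, the one measured step that bears on it is the arrival of methylsulfonyl in place of cyano, a 3.3-fold lower number from compound 1 to compound 2 (0.52 log units; beyond the scatter), a modest step beyond the scatter. That step started from another group and took place on the other core, so it is only a loose guide. A modest step toward a lower number is therefore expected, and a result within the scatter of compound 3 would not be surprising. The estimated step is a 2.3-fold lower number from compound 3 to compound 4 (0.37 log units; beyond the scatter), with the direction taken from that single precedent. For compound 4 the estimated value is 3000 nM (1000 nM to 8000 nM).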

Compound 4, half-maximal inhibitory concentration: 13000 nM
The estimate for compound 4 lay 4.3-fold (0.64 log units) below the measured number; measured number outside the range, above it.
By their numbers in this assay, from the lowest: compound 2; then compounds 3, 1 and 4 (each within the scatter of the next).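

In this assay the exchange of hydroxy for methylsulfonyl on an aromatic carbon para to a large group gives a 1.9-fold higher number from compound 3 to compound 4 (0.27 log units; within the scatter) and so leaves the two compounds within the scatter of each other, which means this read-out does not separate the two groups at this place on the core of compound 3. For the compounds shown here, the one earlier step that brought in methylsulfonyl, a 3.3-fold lower number from compound 1 to compound 2 (0.52 log units; beyond the scatter) on the other core and from cyano rather than hydroxy, finds no match here, and the group does not give the same number on both cores: compound 2 reads 3000 nM while compound 4 reads 13000 nM on the same read-out. No measurement at hand accounts for this outcome, so it stands as an observation only.

From the compounds shown here alone, it remains open whether another group at this place on the core of compound 3, such as an amine, a carboxylic acid or a methoxy group, would move the number beyond the scatter of compound 3. Going by these compounds, it also remains open whether the gap between the two methylsulfonyl compounds would recur with a second group carried on both cores.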